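This account rests on a few compounds, and the source may have more. Where it says the series, first, only, none or still open, it means among the compounds named here.

Measured in a functional assay on HUVEC cells (Homo sapiens) for antiproliferative activity, read by MTT assay, with a stated time of 48 h (a higher number here means a weaker inhibitor, a lower number a stronger inhibitor), so far
Compound 1 `Brc1cccc(/C=C/c2nnc(-c3ccc4c(c3)OCCO4)o2)c1` gives 13500 nM
Compound 2 `Clc1ccccc1/C=C/c1nnc(-c2ccc3c(c2)OCCO3)o1` gives 7710 nM
Compound 3 `Clc1ccc(/C=C/c2nnc(-c3ccc4c(c3)OCCO4)o2)cc1` gives 8030 nM

These three values form a tight group in which compound 3 has no clear rank. The smallest gap that touches it is a 1.0-fold higher number from compound 2 to compound 3 (0.02 log units; within the scatter) and the largest is a 1.7-fold lower number from compound 1 to compound 3 (0.23 log units; within the scatter) and so neither separates it from its neighbours.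

The next compound is compound 4 `COc1cccc(/C=C/c2nnc(-c3ccc4c(c3)OCCO4)o2)c1` with 3-methoxyphenyl in place of 4-chlorophenyl on a double-bonded chain carbon bound to a double-bonded chain carbon while the shared core stays the same. The measured steps that bear on this change are the two above and a 1.8-fold lower number from compound 1 to compound 2 (0.24 log units; within the scatter) and each replaces one aryl group at that same place. Within the data shown here, none of the measured compounds carries 3-methoxyphenyl, so the guidance is indirect. The closest name is the 3-bromophenyl of compound 1 at 13500 nM and this gives a slight lean towards the higher numbers of the group.

The step expected in this assay is a 1.2-fold higher number from compound 3 to compound 4 (0.10 log units; within the scatter) and no change beyond the scatter is expected. Compound 4 is estimated at 10000 nM (expected range 4500 nM to 22000 nM).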

Compound 4, half-maximal inhibitory concentration: > 50000 nM
Compound 4: a limit, no number; the forecaster's own chance of this, stated with the estimate: 5%; middle value at least 5.0-fold (0.69 log units) from the limit.
By their numbers in this assay, from the lowest: compounds 2, 3 and 1 (each within the scatter of the next). At a limit, above all of these: compound 4.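

In this assay, as far as these compounds go, compound 4 gives > 50000 nM, which is a limit of the assay and not a number, so the true size of each step to it remains unknown. The 3-bromophenyl, 2-chlorophenyl and 4-chlorophenyl compounds had all stayed within the scatter of one another, which gave no sign that the aryl group at this place mattered, but 3-methoxyphenyl brings a clear loss of antiproliferative activity: an at least 6.2-fold higher number from compound 3 to compound 4 (0.79 log units; beyond the scatter), an at least 6.4-fold higher number from compound 2 to compound 4 (0.81 log units; beyond the scatter) and an at least 3.7-fold higher number from compound 1 to compound 4 (0.56 log units; beyond the scatter). The last of these is the narrowest comparison, as only methoxy in place of bromo on an aromatic carbon separates the two compounds, and it shows that this exchange alone is enough to move the result beyond the scatter, although the data give no reason for the loss.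

With only one methoxy compound shown, it remains open whether 2-methoxyphenyl or 4-methoxyphenyl would behave like compound 4 or like the chlorophenyl compounds. From the compounds shown here alone, it is also open whether a hydroxyl, an amine or a methyl group on the same aromatic carbon would keep the activity of compound 1.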